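The source may report more compounds than this note shows. Statements on the series, on what has been measured and on what is new or still open speak of the compounds shown alone.

Measured so far in a functional assay on the whole organism (strain Wistar) with Rattus norvegicus as the target, with a stated time of 5 min; a lower number here means that less compound is needed, a higher number that more compound is needed for the effect:

compound 1, `CCC1(CCCCN2CCN(c3ccc(Cl)cc3)CC2)C(=O)Nc2ccccc21`: 10 mg/kg
compound 2, `CCC1(CCCCN2CCN(c3cccc(Cl)c3)CC2)C(=O)Nc2c(Cl)cc(Cl)cc21`: > 20 mg/kg
compound 3, `CC(C)CC1(CCCCN2CCN(c3cccc(Cl)c3)CC2)C(=O)Nc2ccccc21`: 10 mg/kg

The value of compound 2 is a limit of the assay and not a number; that limit, (the limit of > 20 mg/kg in this assay, at which 1 of the 3 values shown sits), is the only one among the three. Compound 3 stands level with compound 1 at the digits recorded, the two values lying within the scatter of each other, so no order between them can be read. Compound 2 gives only a limit and offers no point of comparison for the step at hand.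

The next compound in the series is compound 4, `CCC1(CCCCN2CCN(c3cccc(Cl)c3)CC2)C(=O)Nc2ccccc21`, not yet measured. The change from compound 3 to compound 4 is methyl in place of isopropyl on a saturated chain carbon bound to a saturated ring carbon. Among the measured compounds shown here, no pair of measured compounds differs in exactly this way, so the size of the step is open.

The expectation for compound 4 rests on compound 1, which carries the ethyl group and gives 10 mg/kg, and on compound 3 with 10 mg/kg. Since both sit at the same figure, the step from compound 3 to compound 4 is expected to be none beyond the scatter, no change at the digits printed from compound 3 to compound 4 (within the scatter). Compound 4 is therefore estimated at 10 mg/kg, with a range from 5 mg/kg to 20 mg/kg.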

Compound 4, minimum effective dose: > 20 mg/kg
Compound 4: only a limit was reported; the forecaster's own chance of this, stated with the estimate: 15%; middle value at least 2.0-fold (0.30 log units) from the limit.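

In this assay compound 4 gives > 20 mg/kg, which is a limit of the assay and not a number, and it is the second such entry in the set: the limit of > 20 mg/kg in this assay, at which 2 of the 4 values shown sit. Methyl in place of isopropyl on a saturated chain carbon bound to a saturated ring carbon gives the first step read at this place, an at least 2.0-fold higher number from compound 3 to compound 4 (0.30 log units; that floor lies within the scatter), and because only its floor is known and that floor lies within the scatter, the true size of the step has no upper bound here. 3-chlorophenyl in place of 4-chlorophenyl on an amine nitrogen in a ring gives an at least 2.0-fold higher number from compound 1 to compound 4 (0.30 log units; that floor lies within the scatter), again only a floor within the scatter, so compound 4 now links compound 1 and compound 3 through two single changes, each pointing to a higher number without fixing how much higher.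

From the compounds shown here alone, how far compound 4 lies past the limit stays open, and with it the size of both steps. Also open, going by these compounds, is what a longer chain such as n-hexyl would give at this place, or what an unsubstituted phenyl would give on the amine nitrogen in a ring.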